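Swapping a Ring Hydrogen for Trifluoromethyl: What to Expect

The compounds below may be only part of what the source reports. "The series", "measured", "known", "first", "only" and "open" are said of these compounds alone.

In an assay on COS-1 cells for displacement of a labelled ligand from sodium-dependent dopamine transporter (Homo sapiens) (a lower number here means a stronger inhibitor, a higher number a weaker inhibitor), compound 3 `COC(=O)C1=C(c2ccccc2)CCCC1` gives 630000 nM. Among the three measured compounds this is the second highest number. Compound 1 `COC(=O)C1=C(c2ccc(C(C)(C)C)cc2)CCCC1` gives 605000 nM, which lies within the scatter of compound 3, while compound 2 `COC(=O)C1=C(c2ccc(OC(F)(F)F)cc2)CCCC1` gives 1660000 nM and stands apart by a 2.6-fold lower number from compound 2 to compound 3 (0.42 log units; beyond the scatter). Compound 4 `COC(=O)C1=C(c2ccc(C(F)(F)F)cc2)CCCC1` differs from compound 3 by trifluoromethyl in place of hydrogen on an aromatic carbon. For the measured compounds named here, two measured steps bear on this change, each replacing a group on an aromatic carbon with hydrogen. Taking away tert-butyl gave a 1.0-fold higher number from compound 1 to compound 3 (0.02 log units; within the scatter), a step within the scatter, whereas taking away trifluoromethoxy gave a 2.6-fold lower number from compound 2 to compound 3 (0.42 log units; beyond the scatter), a modest step. Trifluoromethyl, like trifluoromethoxy, carries three fluorine atoms, so a small rise in the number, or no change beyond the scatter, seems the likelier outcome, with the tert-butyl step a reminder that a group here can also leave the number untouched. Compound 4 is therefore estimated at 900000 nM, within a range from 350000 nM to 2300000 nM, which corresponds to an expected step of a 1.4-fold higher number from compound 3 to compound 4 (0.15 log units; within the scatter).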

Compound 4, inhibition constant: 590000 nM
The estimate for compound 4 lay 1.5-fold (0.18 log units) above the measured number; the measured number falls inside the stated range.
By their numbers in this assay, from the lowest: compounds 4, 1 and 3 (each within the scatter of the next); then compound 2.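

Trifluoromethyl on this aromatic carbon brings a 1.1-fold lower number from compound 3 to compound 4 (0.03 log units; within the scatter) and matches tert-butyl, with a 1.0-fold lower number from compound 1 to compound 4 (0.01 log units; within the scatter) as the step between them, so hydrogen, tert-butyl and trifluoromethyl all give numbers within the scatter of one another here. Only trifluoromethoxy stands apart, and the swap to trifluoromethyl brings a 2.8-fold lower number from compound 2 to compound 4 (0.45 log units; beyond the scatter) even though both groups carry three fluorine atoms, so fluorine alone does not go with the higher number in this set, as compound 4 shows. Nothing measured here gives a reason for the gap between these two groups.

On these data alone, what an amine or a carboxylic acid would do on this aromatic carbon remains open. Also open, as far as these compounds go, is whether a change elsewhere on the shared core, such as an amide in place of the ester, would move the number further than any of these groups.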